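The source may report more compounds than this note shows. Statements on the series, on what has been measured and on what is new or still open speak of the compounds shown alone.

Three compounds have been measured in an assay on isolated protein for inhibition of ubiquitin carboxyl-terminal hydrolase 7 (Homo sapiens), read by fluorescence, with stated times of 30 min and 1 h; a lower number here means a stronger inhibitor, a higher number a weaker inhibitor:

Compound 1, `O=C1CCC(=O)N1Cc1cc2nccc(-c3cc(Cl)cc4c3O[C@@H](c3onc5c3CNCC5)C4)c2s1`, gives 0.38 nM.
Compound 2, `Nc1cc(-c2cc(Cl)cc3c2OC(C(=O)N2CCNCC2)C3)ccn1`, gives 5600 nM.
Compound 3, `O=C([C@H]1Cc2cc(Cl)cc(-c3ccnc4ccsc34)c2O1)N1CCNCC1`, gives 90 nM.

Compound 3 therefore stands second highest of the three numbers in this assay: compound 2 sits a good deal higher, beyond the scatter, while compound 1 lies far lower, also beyond the scatter. None of these pairs differs in only one place, so no single step can be read from them.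

Compound 4, `O=C([C@H]1Cc2cc(Cl)cc(-c3ccnc4cc(CO)sc34)c2O1)N1CCNCC1`, has not yet been measured. It differs from compound 3 in one place: hydroxymethyl in place of hydrogen on an aromatic carbon. Going by the values given here, no measured pair shows this change on its own. Among the compounds with values here, the only hint is that compound 1, which carries a group on the same ring and differs elsewhere too, gives 0.38 nM, a very low number. On that basis the step from compound 3 to compound 4 is expected to be a modest improvement, a 3.0-fold lower number from compound 3 to compound 4 (0.48 log units; beyond the scatter), a little beyond the scatter. Compound 4 is estimated at 30 nM, within a range from 8 nM to 120 nM.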

Compound 4, half-maximal inhibitory concentration: 43 nM
Estimate against measurement, compound 4: 1.4-fold (0.16 log units) below; the measured number falls inside the stated range.
By their numbers in this assay, from the lowest: compound 1; then compound 4; then compound 3; then compound 2.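

In this assay, hydroxymethyl in place of hydrogen on an aromatic carbon of the five-membered aromatic ring with 1 sulfur, next to the ring sulfur, gives a 2.1-fold lower number from compound 3 to compound 4 (0.32 log units; beyond the scatter). Going by these compounds alone, this is the first step in the set that can be read on its own, and it shows that this carbon can carry a small group bearing a hydrogen-bond donor and acceptor with a modest gain rather than a loss. The data offer no measured reason for this gain.

The compounds shown leave open how a methyl, an aminomethyl or a carboxylic acid on this carbon would compare with hydroxymethyl, and so whether the oxygen or the added carbon accounts for the step. They also leave open whether hydroxymethyl would give a step of similar size on the core of compound 1.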